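A second nitro group at the assay's limit

The source may report more compounds than this note shows. Statements on the series, on what has been measured and on what is new or still open speak of the compounds shown alone.

In a functional assay, read by spectrophotometry, with a stated time of 30 min (a lower number here means that less compound is needed, a higher number that more compound is needed for the effect), compound 1 `COc1cc(C2Oc3cc([C@H]4Oc5cc(O)cc(O)c5C(=O)[C@@H]4O)ccc3OC2COC(=O)c2ccc(N)cc2)ccc1O` gives 128000 nM.

Compound 2 `COc1cc(C2Oc3cc([C@H]4Oc5cc(O)cc(O)c5C(=O)[C@@H]4O)ccc3OC2COC(=O)c2ccc([N+](=O)[O-])cc2)ccc1O` gives > 300000 nM, which is a limit of the assay and not a number.

Compound 3 `COc1cc(C2Oc3cc([C@H]4Oc5cc(O)cc(O)c5C(=O)[C@@H]4O)ccc3OC2COC(=O)c2cc([N+](=O)[O-])cc([N+](=O)[O-])c2)ccc1O` has 3,5-dinitrophenyl in place of 4-nitrophenyl on a carbonyl carbon.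

Among the measured compounds shown here, one measured step bears on this change: an at least 2.3-fold higher number from compound 1 to compound 2 (0.36 log units; beyond the scatter), where nitro took the place of amino on an aromatic carbon. A modest move in the same direction is therefore expected, estimated as a step that the limit leaves unreadable from compound 2 to compound 3. For compound 3 the estimate is 450000 nM, with an expected range from 200000 nM to 1000000 nM, and this assay may well report only a limit again.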

Compound 3, half-maximal effective concentration: 205000 nM
Compound 3: middle estimate off by 2.2-fold (0.34 log units), on the high side; low and high end bracket the measured number.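

At this place on the carbonyl carbon, the 3,5-dinitrophenyl group gives a readable number in this assay, so a ring bearing nitro groups need not end at a limit, though 4-nitrophenyl does. Replacing 4-aminophenyl with 3,5-dinitrophenyl gives a 1.6-fold higher number from compound 1 to compound 3 (0.20 log units; within the scatter), so these two groups cannot be told apart here. Replacing 4-nitrophenyl with 3,5-dinitrophenyl gives an at least 1.4-fold lower number from compound 2 to compound 3 (0.16 log units; that floor lies within the scatter), a floor and not a measured size, set by a limit: the limit of > 300000 nM in this assay, at which 1 of the 3 values shown sits.

How far one nitro group differs from two therefore stays unread. On these data alone, whether a carboxylic acid or a longer chain on this ring would shift the number beyond the scatter also remains open.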